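Shared core: acetyl in place of dimethylcarbamoyl

This account rests on a few compounds, and the source may have more. Where it says the series, first, only, none or still open, it means among the compounds named here.

Of the compounds shown here, three have been measured in a functional assay on HEK293 cells for agonist activity at transient receptor potential cation channel subfamily V member 1 (Homo sapiens), read by calcium flux; a lower number here means that less compound is needed, a higher number that more compound is needed for the effect. Compound 1 `CC(=O)Cn1nnnc1Cc1ccc(-c2ccccc2)cc1` returns only a limit of the assay, > 100000 nM. Compound 2 `CC(=O)Cn1nnc(Cc2ccc(-c3ccccc3)cc2)n1` likewise reaches only the limit, > 100000 nM. Compound 3 `CN(C)C(=O)Cn1nnc(CNC(=O)c2ccc(-c3ccccc3)cc2)n1` also stops at the limit, > 100000 nM. For the measured compounds named here, compound 3 therefore stands where every value so far stands: the limit of > 100000 nM in this assay, at which 3 of the 3 values shown sit. Going by the values given here, no step between two measured compounds is available, so no step can be sized from the data.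

Compound 4 `CC(=O)Cn1nnc(CNC(=O)c2ccc(-c3ccccc3)cc2)n1` differs from compound 3 in one place: methyl in place of dimethylamino on a carbonyl carbon, that is, dimethylcarbamoyl to acetyl, or (dimethylcarbamoyl)methyl to 2-oxopropyl, on a carbonyl carbon whose other neighbour is a saturated chain carbon. Compound 1 and compound 2 already carry the 2-oxopropyl group and sit at the limit, so that group gives no sign of bringing activity into measurable range in this assay. For compound 4 the same outcome is expected, with a step from compound 3 of a number no higher from compound 3 to compound 4 (the limit leaves the size open) in this assay, none beyond the scatter. Compound 4 is thus estimated at 100000 nM in this assay, within 30000 nM to 300000 nM, the limit being the most probable report.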

Compound 4, half-maximal effective concentration: > 100000 nM
Compound 4 ended at the assay's limit; the forecaster's own chance of this, stated with the estimate: 85%; the middle value sits exactly at the limit.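

Compound 3 and compound 4 both stop at the limit in this assay, so no step can be read for methyl in place of dimethylamino on the carbonyl carbon. The compounds shown leave open whether any change to the shared core gives a measurable value in this assay.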